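Aryl substituent transfer across two solubilising tails

This account rests on a few compounds, and the source may have more. Where it says the series, first, only, none or still open, it means among the compounds named here.

Compound 1 `COc1cc2c(Oc3ccc(NC(=O)c4nnn(-c5ccc(C)cc5)c4C(F)(F)F)cc3F)ccnc2cc1OCCCN1CCC(C)CC1` and compound 2 `COc1cc2c(Oc3ccc(NC(=O)c4nnn(-c5ccc(F)c(F)c5)c4C(F)(F)F)cc3F)ccnc2cc1OCCCN1CCC(C)CC1` share a core; in a functional assay on U-87MG ATCC cells (Homo sapiens) for cytotoxicity, read by MTT assay, with a stated time of 72 h (a lower number here means a stronger inhibitor, a higher number a weaker inhibitor), compound 1 gives 2800 nM and compound 2 gives 1150 nM. The change between them is 3,4-difluorophenyl in place of 4-methylphenyl on an aromatic nitrogen and the step it made was a 2.4-fold lower number from compound 1 to compound 2 (0.39 log units; beyond the scatter). Compound 3 `COc1cc2c(Oc3ccc(NC(=O)c4nnn(-c5ccc(C)cc5)c4C(F)(F)F)cc3F)ccnc2cc1OCCCN1CCN(C)CC1` carries a different tail on the same core; the difference is 4-methylpiperazin-1-yl in place of 4-methylpiperidin-1-yl on a saturated chain carbon, three bonds along the chain from an oxygen on an aromatic ring, and the step was a 1.3-fold lower number from compound 1 to compound 3 (0.11 log units; within the scatter). In this assay compound 3 gives 2170 nM.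

Compound 4 `COc1cc2c(Oc3ccc(NC(=O)c4nnn(-c5ccc(F)c(F)c5)c4C(F)(F)F)cc3F)ccnc2cc1OCCCN1CCN(C)CC1` is compound 3 with the aryl change applied: 3,4-difluorophenyl in place of 4-methylphenyl on an aromatic nitrogen. The two place descriptions agree word for word, so this is the same change seen once before, now on the second tail. Among the measured compounds shown here, only one earlier instance exists, so the expectation rests on that single step and on the tail change being within scatter. For the measured compounds named here, an expected step of a 2.3-fold lower number from compound 3 to compound 4 (0.36 log units; beyond the scatter) is taken for compound 4, set beside the earlier step because a 2.4-fold lower number from compound 1 to compound 2 (0.39 log units; beyond the scatter) is the only measured instance. Compound 4 is therefore estimated at 950 nM in this assay, with the expected range 450 nM to 2000 nM.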

Compound 4, half-maximal inhibitory concentration: 1390 nM
For compound 4 the middle estimate is 1.5-fold (0.17 log units) below the measured one, within the range that was stated.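

On the 4-methylpiperazin-1-yl tail, 3,4-difluorophenyl in place of 4-methylphenyl gives a 1.6-fold lower number from compound 3 to compound 4 (0.19 log units; within the scatter) in this assay, and this step does not differ from the one on the 4-methylpiperidin-1-yl tail: the same change on two cores in this assay, a 2.4-fold lower number (0.39 log units; beyond the scatter) from compound 1 to compound 2 and a 1.6-fold lower number (0.19 log units; within the scatter) from compound 3 to compound 4, 1.6-fold (0.19 log units) apart, within the scatter of two such steps. The tail change, read with 3,4-difluorophenyl on the aromatic nitrogen, gives a 1.2-fold higher number from compound 2 to compound 4 (0.08 log units; within the scatter), and it also agrees with its earlier instance: the same change on two cores in this assay, a 1.3-fold lower number (0.11 log units; within the scatter) from compound 1 to compound 3 and a 1.2-fold higher number (0.08 log units; within the scatter) from compound 2 to compound 4, 1.6-fold (0.19 log units) apart, within the scatter of two such steps. Both changes therefore carry from one core to the other within the scatter, but each comparison rests on a single pair of steps in one assay, and the aryl change is beyond the scatter only on the 4-methylpiperidin-1-yl tail, so a real gain on the 4-methylpiperazin-1-yl tail is not established.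

Going by these compounds, it remains open whether this agreement extends to other aryl groups on the aromatic nitrogen, such as 4-chlorophenyl or 4-methoxyphenyl. The same question applies to other amines at the end of the chain, such as morpholine or dimethylamine.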